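Methyl in place of hydrogen on a phenolic oxygen

The source may hold more compounds than are shown below. What is called first, only, known or untested is meant among the compounds shown, and "the series" means these compounds.

Of the compounds shown here, three have so far been tested in a functional assay on K562 cells (Homo sapiens) for inhibition, read by sulforhodamine B assay, with a stated time of 48 h; on this read-out lower numbers stand for stronger inhibition of growth and higher numbers for weaker inhibition of growth. Compound 1 `COc1ccc(/C=C/C2(C)C=CC(=O)O2)c(OC)c1OC` gives a value that is a limit of the assay, > 1000000 nM. Compound 2 `COc1c(O)ccc(/C=C/C2(C)C=CC(=O)O2)c1OC` likewise gives only a limit, > 1000000 nM. Compound 3 `CC1(/C=C/c2ccccc2O)C=CC(=O)O1` also sits at a limit, > 1000000 nM. From compound 2 to compound 1 the change is methyl in place of hydrogen on an oxygen on an aromatic ring, and the step it made is a step that the two limits leave unreadable from compound 2 to compound 1. The difference between the cores of compound 3 and compound 2 is not broken down here. Compound 4 `COc1ccccc1/C=C/C1(C)C=CC(=O)O1` has not yet been measured; it differs from compound 3 by methyl in place of hydrogen on an oxygen on an aromatic ring, the same change seen between compound 2 and compound 1. For compound 4 the expected step from compound 3 is a number no higher from compound 3 to compound 4 (the limit leaves the size open), resting on (the limit of > 1000000 nM in this assay, at which 3 of the 3 values shown sit). Compound 4 is therefore estimated at 1000000 nM, most likely reported again only as a limit.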

Compound 4, concentration for total growth inhibition: 860000 nM
Beside the measured number, compound 4's estimate is 1.2-fold (0.07 log units) above it; the measured number falls inside the stated range.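

In this assay, hydroxy to methoxy on the aromatic ring gives an at least 1.1-fold lower number from compound 3 to compound 4 (0.06 log units; that floor lies within the scatter), so this change on this core shows no shift that can be told from the scatter. From the compounds shown here alone, the true size of that step stays open, as the value of compound 3 is only a limit. The same change on the core of compound 2 cannot be read, so the data neither support nor refute its carrying over from one core to the other: the limit of > 1000000 nM in this assay, at which 3 of the 4 values shown sit.

The compounds shown leave open whether an amine or a carboxylic acid on the aromatic ring would bring the numbers clear of that limit. They also leave open what a longer chain in place of the methyl on the oxygen would do.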